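The source may hold more compounds than are shown below. What is called first, only, known or untested is meant among the compounds shown, and "the series" means these compounds.

Four compounds built on the same core are compared here: compound 1 `COC(=O)C1=CO[C@@H](O[C@@H]2O[C@H](COC(c3ccccc3)(c3ccccc3)c3ccccc3)[C@@H](O)[C@H](O)[C@H]2O)[C@@H]2[C@@H](C)[C@@H](O)C[C@H]12`, compound 2 `CCC(=O)OC[C@H]1O[C@@H](O[C@@H]2OC=C(C(=O)OC)[C@H]3C[C@H](OC(C)=O)[C@H](C)[C@@H]23)[C@H](OC(C)=O)[C@@H](OC(C)=O)[C@@H]1OC(C)=O`, compound 3 `CCCCCCCCCCCCCCCC(=O)OC[C@H]1O[C@@H](O[C@@H]2OC=C(C(=O)OC)[C@H]3C[C@H](OC(C)=O)[C@H](C)[C@@H]23)[C@H](OC(C)=O)[C@@H](OC(C)=O)[C@@H]1OC(C)=O` and compound 4 `COC(=O)C1=CO[C@@H](O[C@@H]2O[C@H](COC(=O)c3cccc([N+](=O)[O-])c3)[C@@H](OC(C)=O)[C@H](OC(C)=O)[C@H]2OC(C)=O)[C@@H]2[C@@H](C)[C@@H](OC(C)=O)C[C@H]12`. In a functional assay on Caco-2 cells (Homo sapiens) for cytotoxicity, read by MTT assay, with a stated time of 4 h (a higher number here means a weaker inhibitor, a lower number a stronger inhibitor), compound 1 gives 0.56 ug/mL, and compound 2 gives 2.85 ug/mL. Compound 2 therefore has the higher number of the two, which marks it as the weaker inhibitor, and the gap lies beyond the usual scatter. With hexadecanoyl where compound 2 has propanoyl, compound 3 is reported only as "not active" (no number reported), without a number.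

Compound 4 differs from compound 2 in one group: 3-nitrophenyl in place of ethyl on a carbonyl carbon. In words, 3-nitrophenyl replaces ethyl on a carbonyl carbon, turning propanoyl into (3-nitrophenyl)carbonyl. Among the measured compounds shown here, no measured pair in this assay shows this change, so the expectation is loose. A larger group in compound 3, reported as "not active" (no number reported), leaves a real chance that no number appears at all. The estimated step of a 1.4-fold higher number from compound 2 to compound 4 (0.15 log units; within the scatter) is expected to stay within the scatter, leaning slightly towards weaker. For compound 4 the expected value is 4 ug/mL, with an estimated range of 1 ug/mL to 20 ug/mL.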

Compound 4, half-maximal inhibitory concentration: 1 ug/mL
The estimate for compound 4 lay 4.0-fold (0.60 log units) above the measured number; the measured number falls inside the stated range.
By their numbers in this assay, from the lowest: compounds 1 and 4 (each within the scatter of the next); then compound 2.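

In this assay, replacing ethyl with 3-nitrophenyl on a carbonyl carbon gives a 2.9-fold lower number from compound 2 to compound 4 (0.45 log units; beyond the scatter), a modest step towards a stronger inhibitor. This shows that a group with more heavy atoms than ethyl can sit at this position and still give a number, whereas compound 3, which carries hexadecanoyl, is reported as "not active" (no number reported), so adding heavy atoms here does not always end in the same result. Nothing measured here explains the direction of this step.

The compounds shown leave open whether the step comes from the aromatic ring or from the nitro group, which plain phenyl or an amine in place of the nitro group could separate. They also leave open how a chain of intermediate length, such as octanoyl, would behave between propanoyl and hexadecanoyl.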